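Compound 3: carboxy replacing the formylamino side chain

A few compounds are considered here, and "the series" means these few. Any claim that something is new, unique, unknown or untested is made for them only; others in the source may bear on it.

Measured so far in a functional assay on HT-29 cells (Homo sapiens) for inhibition, read by sulforhodamine B assay, with a stated time of 48 h (a lower number here means a stronger inhibitor of growth, a higher number a weaker inhibitor of growth), for each compound:
compound 1 `O=C(NNC(=O)c1ccc2[nH]c(-c3ccc([N+](=O)[O-])o3)nc2c1)c1ccccc1` gives 31.3 ug/mL
compound 2 `O=CNNC(=O)c1ccc2[nH]c(-c3ccc([N+](=O)[O-])o3)nc2c1` gives 62.5 ug/mL

Among the compounds with values here, compound 2 stands within the scatter of compound 1, the only other measured compound. Next is compound 3 `O=C(O)c1ccc2[nH]c(-c3ccc([N+](=O)[O-])o3)nc2c1`, with hydroxy in place of (formylamino)amino on a carbonyl carbon. Within the data shown here, the one measured step is a 2.0-fold higher number from compound 1 to compound 2 (0.30 log units; within the scatter) and lies within the scatter. Among the measured compounds shown here, it is a limited guide, as no measured compound carries the hydroxy. No step beyond the scatter is therefore expected in this assay in either direction, and the estimate means no change at the digits printed from compound 2 to compound 3 (within the scatter) as the expected step. Compound 3 is expected at 62.5 ug/mL with an estimated range from 20 ug/mL to 200 ug/mL for now.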

Compound 3, concentration for 50% growth inhibition: 250 ug/mL
For compound 3 the middle estimate is 4.0-fold (0.60 log units) below the measured one; the measured number lies above the stated range.
By their numbers in this assay, from the lowest: compounds 1 and 2 (each within the scatter of the next); then compound 3.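

In this assay, within the data shown here, cutting (formylamino)carbamoyl back to carboxy gives a 4.0-fold higher number from compound 2 to compound 3 (0.60 log units; beyond the scatter), the first step beyond the scatter. The carbonyl carbon on the aromatic carbon therefore responds to this change, whereas replacing phenyl with hydrogen further out on the side chain did not move the number beyond the scatter. Nothing at hand accounts for this step.

On these data alone, whether a methyl ester or a simple carboxamide at this place would read closer to compound 2 or to compound 3 remains open. So does the outcome with a longer acyl chain on the hydrazide.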